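Triazole benzyl substituent variation on a flavanone core

The source may report more compounds than this note shows. Statements on the series, on what has been measured and on what is new or still open speak of the compounds shown alone.

Compound 3 `COc1ccc([C@@H]2CC(=O)c3c(O)cc(OCc4cn(Cc5ccccc5F)nn4)cc3O2)cc1O` gives the lowest number of the three measured in a functional assay on RAW264.7 cells (Mus musculus) for inhibition, read by Griess assay, with stated times of 2 h and 24 h (a higher number here means a weaker inhibitor, a lower number a stronger inhibitor), with 7320 nM; compound 2 `CCCn1cc(COc2cc(O)c3c(c2)O[C@H](c2ccc(OC)c(O)c2)CC3=O)nn1` gives 9670 nM, and compound 1 `COc1ccc([C@@H]2CC(=O)c3c(O)cc(OCc4cn(Cc5cccc(Cl)c5)nn4)cc3O2)cc1O` gives 18200 nM. The step of a 2.5-fold lower number from compound 1 to compound 3 (0.40 log units; beyond the scatter) was modest, whereas a 1.9-fold lower number from compound 1 to compound 2 (0.27 log units; within the scatter) and a 1.3-fold lower number from compound 2 to compound 3 (0.12 log units; within the scatter) were both small. Compound 4 `COc1ccc([C@@H]2CC(=O)c3c(O)cc(OCc4cn(Cc5cccc(C)c5)nn4)cc3O2)cc1O` differs from compound 3 by 3-methylphenyl in place of 2-fluorophenyl on a saturated chain carbon bound to an aromatic nitrogen. For the measured compounds named here, since every change at this position so far moved the number by little, the step to compound 4 in this assay is expected to stay small, likely within the scatter, as a 1.2-fold higher number from compound 3 to compound 4 (0.06 log units; within the scatter). Compound 4 is therefore estimated at 8500 nM, within a range from 3500 nM to 20000 nM.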

Compound 4, half-maximal inhibitory concentration: 17400 nM
Compound 4: middle estimate off by 2.0-fold (0.31 log units), on the low side; measured number inside the range.
By their numbers in this assay, from the lowest: compounds 3, 2, 4 and 1 (each within the scatter of the next, the first and the last beyond it).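

The change from 2-fluorobenzyl to 3-methylbenzyl gave a 2.4-fold higher number from compound 3 to compound 4 (0.38 log units; beyond the scatter) in this assay, so this position is less flat than the earlier small steps suggested. Two other steps stay within the scatter: methyl in place of chloro on an aromatic carbon, with a 1.0-fold lower number from compound 1 to compound 4 (0.02 log units; within the scatter), and 3-methylphenyl in place of ethyl, with a 1.8-fold higher number from compound 2 to compound 4 (0.26 log units; within the scatter). Nothing available explains why these steps differ in size. The 2-fluorophenyl and 3-methylphenyl groups differ in both substituent and its numbered place. The compounds shown cannot separate those two changes. Going by these compounds, how an amine or a carboxylic acid on the phenyl ring would read here remains open.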